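This account rests on a few compounds, and the source may have more. Where it says the series, first, only, none or still open, it means among the compounds named here.

In a functional assay on P388 cells (Mus musculus) for cytotoxicity (a lower number here means a stronger inhibitor, a higher number a weaker inhibitor), compound 1 `Cc1cc(-c2c(F)cc3c(=O)c(Cc4cccc(O)c4O)cn(C4CC4)c3c2F)cc(C)n1` gives 880 nM, compound 2 `Cc1cc(-c2c(F)cc3c(=O)c(Cc4ccc(O)cc4O)cn(C4CC4)c3c2F)cc(C)n1` gives 210 nM and compound 3 `Cc1cc(-c2c(F)cc3c(=O)c(Cc4ccccc4N)cn(C4CC4)c3c2F)cc(C)n1` gives 2100 nM. Compound 3 therefore has the highest number of the three and is the weakest inhibitor so far, with its steps to both others beyond the scatter.

The next structure is compound 4 `Cc1cc(-c2c(F)cc3c(=O)c(Cc4c(O)cc(O)cc4O)cn(C4CC4)c3c2F)cc(C)n1`. It carries 2,4,6-trihydroxyphenyl in place of 2-aminophenyl on a saturated chain carbon bound to an aromatic carbon.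

Among the measured compounds shown here, two measured steps bear most directly on this change: a 2.4-fold higher number from compound 1 to compound 3 (0.38 log units; beyond the scatter) and a 10-fold higher number from compound 2 to compound 3 (1.00 log units; beyond the scatter). Both lead to compound 3 from a dihydroxyphenyl compound, so the change to compound 4 runs the opposite way. However, a 4.2-fold lower number from compound 1 to compound 2 (0.62 log units; beyond the scatter) shows that the number also moves with the arrangement of the hydroxy groups, and no measured compound carries 2,4,6-trihydroxyphenyl. A lower number beyond the scatter is therefore expected, of similar size to those two steps.

In this assay, the expected step is a 4.7-fold lower number from compound 3 to compound 4 (0.67 log units; beyond the scatter). Compound 4 is estimated at 450 nM, with an expected range from 120 nM to 1500 nM.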

Compound 4, half-maximal inhibitory concentration: 470 nM
Compound 4: middle estimate off by 1.0-fold (0.02 log units), on the low side, within the range that was stated.
By their numbers in this assay, from the lowest: compound 2; then compounds 4 and 1 (each within the scatter of the next); then compound 3.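

Hydroxy in place of hydrogen on an aromatic carbon does not lower the number at this place: in this assay the step is a 2.2-fold higher number from compound 2 to compound 4 (0.35 log units; beyond the scatter) and stays beyond the scatter, so 2,4-dihydroxyphenyl keeps the lower number. 2,4,6-Trihydroxyphenyl nevertheless holds a clear lead over 2-aminophenyl, with a 4.5-fold lower number from compound 3 to compound 4 (0.65 log units; beyond the scatter) on this change. Against 2,3-dihydroxyphenyl it shows a 1.9-fold lower number from compound 1 to compound 4 (0.27 log units; within the scatter) and cannot be separated from that group, so among these compounds the count of hydroxy groups alone does not set the number.

Open, as far as these compounds go, is whether methoxy in place of any of these hydroxy groups keeps the number of compound 2 in this series. A carboxylic acid on the same ring also remains untested among the compounds shown. No data here give a cause for these differences.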